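Furan for phenyl on a pyrazoline core: cytotoxicity outlook

The compounds below may be only part of what the source reports. "The series", "measured", "known", "first", "only" and "open" are said of these compounds alone.

Compound 1 `O=C(c1ccncc1)N1N=C(c2cc3ccccc3o2)CC1c1ccccc1`: > 209000 nM
Compound 2 `O=C(c1ccncc1)N1N=C(c2cc3ccccc3o2)CC1c1ccco1`: > 208000 nM
Compound 3 `CCn1cc(C(=O)N2N=C(c3cc4ccccc4o3)CC2c2ccccc2)c(=O)c2ccc(C)nc21`: > 210000 nM

Of the compounds shown here, three have been tested in an ADME assay on Vero cells (Chlorocebus sabaeus) for cytotoxicity, read by MTT assay, with a stated time of 72 h (a higher number here means a weaker inhibitor, a lower number a stronger inhibitor), so far. Compound 1 `O=C(c1ccncc1)N1N=C(c2cc3ccccc3o2)CC1c1ccccc1` reaches only a limit of the assay, giving > 209000 nM. Compound 2 `O=C(c1ccncc1)N1N=C(c2cc3ccccc3o2)CC1c1ccco1` likewise stops at a limit of the assay, at > 208000 nM. Compound 3 `CCn1cc(C(=O)N2N=C(c3cc4ccccc4o3)CC2c2ccccc2)c(=O)c2ccc(C)nc21` also gives only a limit of the assay, > 210000 nM. The change from compound 1 to compound 2 is furan-2-yl in place of phenyl on a saturated ring carbon, and its step in this assay, a step that the two limits leave unreadable from compound 1 to compound 2, cannot be read because both values sit at limits, as shown by the limit of > 209000 nM in this assay, at which 1 of the 3 values shown sits, and (the limit of > 208000 nM in this assay, at which 1 of the 3 values shown sits).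

Compound 4 `CCn1cc(C(=O)N2N=C(c3cc4ccccc4o3)CC2c2ccco2)c(=O)c2ccc(C)nc21` is not yet measured. It differs from compound 3 by furan-2-yl in place of phenyl on a saturated ring carbon, the same kind of change as that from compound 1 to compound 2; around the place, the ring atom next to the changed carbon bears a large group in compound 3 where it bears a (pyridin-4-yl)carbonyl group in compound 1. The difference between the core of compound 1 and the core of compound 3 is not broken down here.

Since compound 3 sits at a limit, as the limit of > 210000 nM in this assay, at which 1 of the 3 values shown sits, records, and the earlier step of the same kind left both partners at limits, compound 4 is expected to remain at a limit as well, with an estimated step of a number no higher from compound 3 to compound 4 (the limit leaves the size open). For compound 4 the estimate in this assay is 210000 nM, between 100000 nM and 450000 nM.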

Compound 4, half-maximal inhibitory concentration: > 185000 nM
Compound 4 gave a limit, no number (the forecaster's own chance of this, stated with the estimate: 85%); the middle value is on the limit's open side.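

In this assay compound 4 also stops at a limit of the assay, > 185000 nM. Compound 3 sits at a limit too, so the step between compound 3 and compound 4 cannot be read, and no new comparison arises. The four compounds leave open how large any effect of furan-2-yl in place of phenyl is on either core, and what actual number any of them would give.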